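Notes on the acyl change from compound 2 to compound 4

The source may report more compounds than this note shows. Statements on the series, on what has been measured and on what is new or still open speak of the compounds shown alone.

The set is tested in an assay on CHO cells for positive allosteric modulation of metabotropic glutamate receptor 5 (Homo sapiens), read by FLIPR; on this read-out higher numbers stand for an effect only at larger amounts of compound and lower numbers for an effect already at smaller amounts. Compound 1 `O=C(Nc1cccc(F)c1CN1C(=O)c2ccccc2C1=O)c1ccccn1` returns only the limit > 100000 nM in this assay. Among the compounds with values here, compound 3 `O=C(Nc1ccccc1CN1C(=O)c2ccccc2C1=O)c1ccccn1`, which carries hydrogen in place of fluoro on an aromatic carbon, gives 13900 nM in this assay, and the step of an at least 7.1-fold lower number from compound 1 to compound 3 (0.85 log units; beyond the scatter) is the only measured step in the set. Compound 2 `O=C(Nc1ccc(Cl)cc1CN1C(=O)c2ccccc2C1=O)c1ccccc1` also returns only the limit > 100000 nM in this assay. Compound 2 thus stands with compound 1 among the values covered by the limit of > 100000 nM in this assay, at which 2 of the 3 values shown sit, without a number of its own.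

Compound 4 `O=C(Nc1ccc(Cl)cc1CN1C(=O)c2ccccc2C1=O)c1ncccc1O` differs from compound 2 by 3-hydroxypyridin-2-yl in place of phenyl on a carbonyl carbon. Within the data shown here, no measured step bears on this change directly: the step of an at least 7.1-fold lower number from compound 1 to compound 3 (0.85 log units; beyond the scatter) concerns a substituent on the anilide ring, not the acyl group. Among the measured compounds shown here, compound 2 and compound 3 differ in two places, so their values show only that one pair sits at the limit and the other gives a number.

Given that compound 2 sits at the limit > 100000 nM, a step toward lower numbers of an at least 2.0-fold lower number from compound 2 to compound 4 (0.30 log units; that floor lies within the scatter) is expected, with a real chance that only a limit is returned again. Compound 4 is estimated at 50000 nM, within 10000 nM to 200000 nM.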

Compound 4, half-maximal effective concentration: 260 nM
For compound 4 the middle estimate is 190-fold (2.28 log units) above the measured one, and the stated range ends above it.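

In this assay, 3-hydroxypyridin-2-yl in place of phenyl on a carbonyl carbon gives an at least 380-fold lower number from compound 2 to compound 4 (2.58 log units; beyond the scatter), which makes the acyl group a place where one change moves the read-out by a large amount. Within the data shown here, until now the only measured step was an at least 7.1-fold lower number from compound 1 to compound 3 (0.85 log units; beyond the scatter), which concerned hydrogen in place of fluoro on an aromatic carbon and said nothing about the acyl group. The value of compound 2 is a limit and not a number, so the printed step is only a floor and its full size stays unknown: the limit of > 100000 nM in this assay, at which 2 of the 4 values shown sit.

The change brings in a ring nitrogen and a hydroxy group together, and no pair of compounds shown separates the two, so it remains open which of them accounts for the step. Also open, from the compounds shown here alone, is whether a methoxy or an amino group in place of the hydroxy would keep a value like that of compound 4 at 260 nM, and whether the same acyl group would act alike on a core without the chloro.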